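Cyclobutyloxy Replaced by Azetidin-1-yl in Three Compounds

The compounds below may be only part of what the source reports. "The series", "measured", "known", "first", "only" and "open" are said of these compounds alone.

Measured so far:
compound 1 `Cc1nc(OC2CCC2)nc(N2CCC2)c1O` 96%
compound 2 `CCCCCCCCCCCCCCCCc1nc(OC2CCC2)nc(N2CCC2)c1O` 99%
compound 3 `CCCCCCCCCCCCCCCCc1nc(OC2CCC2)nc(OC2CCC2)c1O` 96%

In a functional assay on cells (Lymphocyte, Homo sapiens), read by a luciferase reporter and ATP content, with a stated time of 48 h, tested at 20 uM (on this read-out lower numbers stand for a stronger effect and higher numbers for a weaker effect at the one concentration tested), the three compounds sit close together. Compound 1 stands level with compound 3 at the digits given, and the difference between their two cores is not broken down here. Compound 3 and compound 2 differ in one place: azetidin-1-yl in place of cyclobutyloxy on an aromatic carbon. That change gave a number 3 percentage points higher from compound 3 to compound 2 (within the scatter), so both compounds of that pair are within the scatter of each other.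

Compound 4 `Cc1nc(N2CCC2)nc(N2CCC2)c1O` has not yet been measured. It differs from compound 1 by azetidin-1-yl in place of cyclobutyloxy on an aromatic carbon. Among the measured compounds shown here, this is the same kind of change as the one from compound 3 to compound 2, but not the same: here the group stands between two ring nitrogen atoms, meta to a methyl group, meta to an azetidin-1-yl group and para to a hydroxy group, whereas in the other pair it stands next to the ring nitrogen, ortho to a hydroxy group and meta to a cyclobutyloxy group. Resting on the measured step of a number 3 percentage points higher from compound 3 to compound 2 (within the scatter), the expected step from compound 1 to compound 4 is a number 1 percentage points higher from compound 1 to compound 4 (within the scatter). For compound 4 the estimate in this assay is 97%, expected between 86% and 106%.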

Compound 4, a percentage reported as activity, at one concentration (the size of the read-out at that concentration, not a potency): 85%
For compound 4 the middle estimate is 12 percentage points above the measured one, outside the stated range (below it).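

In this assay, azetidin-1-yl in place of cyclobutyloxy on an aromatic carbon gave a number 11 percentage points lower from compound 1 to compound 4 (beyond the scatter). Set beside the earlier step on the other core, this result does not separate from it: the same change on two cores in this assay, a number 3 percentage points higher (within the scatter) from compound 3 to compound 2 and a number 11 percentage points lower (beyond the scatter) from compound 1 to compound 4, 14 percentage points apart, within the scatter of two such steps. The change therefore lowered the number on the core of compound 1 but gave no step beyond the scatter on the core of compound 3, yet these two steps do not show that the core decides the outcome, and they give no firm rule for carrying the change to a further core in this series.

The compounds shown leave open how the same change would behave on a core carrying a chain of intermediate length in place of the methyl group, since only the two extremes of chain length appear here. They also leave open whether a larger ring such as pyrrolidin-1-yl, or a small open group such as methoxy, would give a similar result in the place held by cyclobutyloxy.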